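This account rests on a few compounds, and the source may have more. Where it says the series, first, only, none or still open, it means among the compounds named here.

- compound 1 `CN(C)S(=O)(=O)c1ccc(F)c(C#Cc2cc(Cl)ccc2OCC(=O)O)c1` - 0.009
- compound 2 `Cc1ccc(S(=O)(=O)NC(C)C)cc1C#Cc1cc(Cl)ccc1OCC(=O)O` - 0.004
- compound 3 `Cc1ccc(S(=O)(=O)CC(C)C)cc1C#Cc1cc(Cl)ccc1OCC(=O)O` - "not determined" (no result reported)

These results come from an ADME assay on a cell-free system (plasma, Homo sapiens); a higher number here means a larger unbound share of the compound, a lower number a smaller unbound share. No number is available for compound 3, so it gives no fixed starting point. The next structure, compound 4 `Cc1ccc(S(=O)(=O)N(C)C)cc1C#Cc1cc(Cl)ccc1OCC(=O)O`, has dimethylamino in place of isobutyl on a sulfonyl sulfur, a change from isobutylsulfonyl to dimethylsulfamoyl: dimethylamino in place of isobutyl on a sulfonyl sulfur. With no measured value on the compound 3 side, the size and direction of this step in this assay cannot be stated. For the measured compounds named here, the only guides are two small numbers, 0.009 for compound 1 and 0.004 for compound 2, and a result in that same low region is expected. For compound 4 the estimated value is 0.006, with an expected range of 0.003 to 0.012.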

Compound 4, unbound fraction: 0.004
Beside the measured number, compound 4's estimate is 1.5-fold (0.18 log units) above it, and the stated range covers the measured number.
By their numbers in this assay, from the lowest: compounds 2 and 4 (each within the scatter of the next); then compound 1.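

In this assay, putting dimethylamino in place of isopropylamino on a sulfonyl sulfur gives no change at the digits printed from compound 2 to compound 4 (within the scatter), so this swap leaves the number where it was. Methyl in place of fluoro on an aromatic carbon gives a 2.3-fold lower number from compound 1 to compound 4 (0.35 log units; beyond the scatter), the only one of these two steps that goes beyond the scatter. Compound 3 has no number, so the change from isobutyl to dimethylamino cannot be read, and no measurement here explains either step.

As far as these compounds go, whether methoxy or ethyl on that aromatic carbon would match methyl or fluoro remains open. So does what a morpholine on the sulfonyl sulfur would do in this assay.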